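This account rests on a few compounds, and the source may have more. Where it says the series, first, only, none or still open, it means among the compounds named here.

Of the compounds shown here, three have so far been measured in a functional assay on KG-1 cells (Homo sapiens) for cytotoxicity, read by luminescence and CellTiter-Glo, with a stated time of 3 days; on this read-out lower numbers stand for stronger inhibition and higher numbers for weaker inhibition. Compound 1 `Cc1ccc(O)c(C(=O)Nc2ccc(C#N)cc2)c1` gives 3370 nM there, the second highest of the three numbers. Compound 2 `N#Cc1ccc(NC(=O)c2cc(Cl)c(-c3ccccc3)cc2O)cc1` gives 480 nM in this assay, a lower number than compound 1 and beyond the scatter. Compound 3 `N#Cc1cccc(NC(=O)c2cc(F)ccc2O)c1` gives 9100 nM in this assay, a higher number than compound 1, also beyond the scatter. No two of these measured compounds differ in one place only, so no single step can be read off. Compound 4 `N#Cc1ccc(NC(=O)c2ccccc2O)cc1` is not yet measured; it differs from compound 1 by hydrogen in place of methyl on an aromatic carbon. Without a measured step to lean on, the expected step of a 1.3-fold higher number from compound 1 to compound 4 (0.13 log units; within the scatter) is small, toward a higher number, and may stay within the scatter. Compound 4 is expected to give about 4500 nM in this assay, within a range from 1500 nM to 13000 nM.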

Compound 4, half-maximal inhibitory concentration: 5370 nM
Estimate against measurement, compound 4: 1.2-fold (0.08 log units) below; low and high end bracket the measured number.
By their numbers in this assay, from the lowest: compound 2; then compounds 1, 4 and 3 (each within the scatter of the next, the first and the last beyond it).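

Going by these compounds alone, this is the first step that can be read at this position, para to a hydroxy group. With hydrogen in place of methyl, the step of a 1.6-fold higher number from compound 1 to compound 4 (0.20 log units; within the scatter) lies within the scatter, so in this assay the methyl group on this aromatic carbon is not shown to change the number. No measured evidence here explains this result. As far as these compounds go, what remains open is whether a different group on this same carbon, such as a methoxy group, an amine or a longer chain, would move the number beyond the scatter.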